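From compound 2 to compound 4: methyl on sulfur

A few compounds are considered here, and "the series" means these few. Any claim that something is new, unique, unknown or untested is made for them only; others in the source may bear on it.

Measured values in a functional assay on ASPC1 cells (Homo sapiens) for inhibition, read by MTT assay, with a stated time of 96 h (on this read-out lower numbers stand for stronger inhibition of growth and higher numbers for weaker inhibition of growth), follow
- compound 1 `O=C(NCCCCCCSSCCCCCCNC(=O)c1cc(-c2ccncc2)n[nH]1)c1cc(-c2ccncc2)n[nH]1` gives 25300 nM
- compound 2 `C=CCOC(=O)SCCCCCCNC(=O)c1cc(-c2ccncc2)n[nH]1` gives 27500 nM
- compound 3 `CCCCCCCC/C=C\CCCCCCCC(=O)SCCCCCCNC(=O)c1cc(-c2ccncc2)n[nH]1` gives > 50000 nM (a limit)

Compound 2 sits within the scatter of compound 1, so these two values show no order. The value of compound 3 is a limit and not a number. Compound 4 `CSCCCCCCNC(=O)c1cc(-c2ccncc2)n[nH]1` carries methyl in place of allyloxycarbonyl on a sulfur and is not yet measured. Within the data shown here, no measured step isolates this change. Among the measured compounds shown here, compound 1 at 25300 nM and compound 2 at 27500 nM are the only numbers available, so a modest shift toward weaker inhibition of growth is expected in this assay with an uncertain size. The estimated shift is a 1.3-fold higher number from compound 2 to compound 4 (0.10 log units; within the scatter) as a working expectation. For compound 4 the estimated value is 35000 nM with an expected range of 17000 nM to 60000 nM and a limit reading remains possible.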

Compound 4, concentration for 50% growth inhibition: > 50000 nM
Compound 4: no number, only a limit (the forecaster's own chance of this, stated with the estimate: 45%); middle value at least 1.4-fold (0.15 log units) away from the limit.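

In this assay, among these compounds, this is the first measured single change on the sulfur, and compound 4 gives > 50000 nM, which is a limit and not a number. On these data alone, the step reads an at least 1.8-fold higher number from compound 2 to compound 4 (0.25 log units; that floor lies within the scatter), so methyl in place of allyloxycarbonyl brings no gain in inhibition of growth, while the true size of the step remains unknown. Compound 4 and compound 3 cannot be ordered: the limit of > 50000 nM in this assay, at which 2 of the 4 values shown sit.

Still open, as far as these compounds go, is whether a free thiol or an acetyl group on the sulfur would give a number rather than a limit. From the compounds shown here alone, the effect of a longer chain on the sulfur is also open.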